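The compounds below may be only part of what the source reports. "The series", "measured", "known", "first", "only" and "open" are said of these compounds alone.

Measured so far:
compound 1 `CNC(c1ccc(/C=C/C#N)cc1)c1ccnc(Nc2ccc(C#N)cc2)n1` — 41400 nM
compound 2 `CC(O)CNC(c1ccc(C#N)cc1)c1ccnc(Nc2ccc(C#N)cc2)n1` — > 65000 nM
compound 3 `CC(C)NC(c1ccnc(Nc2ccc(C#N)cc2)n1)c1ccccc1Cl` — 35500 nM

Of the compounds shown here, three sharing the core of compound 1 have been tested in an ADME assay on MT4 cells (Homo sapiens) for cytotoxicity, read by MTT assay, with a stated time of 5 days; a lower number here means that less compound is tolerated, a higher number that more compound is tolerated. Compound 1 gives 41400 nM in this assay. Compound 3 gives 35500 nM in this assay. Compound 2 gives > 65000 nM, which is a limit of this assay rather than a number, a point marked by the limit of > 65000 nM in this assay, at which 1 of the 3 values shown sits. Of the two numbered results, compound 1 sits at the top, but its distance to compound 3 falls within the usual scatter, so the two read as alike and neither can be called the better tolerated.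

Compound 4 `N#C/C=C/c1ccc(C(NO)c2ccnc(Nc3ccc(C#N)cc3)n2)cc1` is the next compound to be tested in this assay. It differs from compound 1 in one place: hydroxy in place of methyl on an amine nitrogen. Within the data shown here, no pair of measured compounds shows the effect of a change of this kind, so there is nothing to lean on but the spread of the three results, which is small. The step from compound 1 to compound 4 is therefore expected to be slight, in either direction, and is estimated at a 1.1-fold higher number from compound 1 to compound 4 (0.04 log units; within the scatter). Compound 4 is expected to give about 45000 nM in this assay, estimated to lie between 20000 nM and 90000 nM.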

Compound 4, half-maximal cytotoxic concentration: 161000 nM
Estimate against measurement, compound 4: 3.6-fold (0.55 log units) below, outside the stated range (above it).
By their numbers in this assay, from the lowest: compounds 3 and 1 (each within the scatter of the next); then compound 4.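

Among these compounds, this is the first step between compounds that differ in one place, and it shows that the group on this amine nitrogen matters: in this assay, methylamino to hydroxyamino gives a 3.9-fold higher number from compound 1 to compound 4 (0.59 log units; beyond the scatter), a modest step but one beyond the scatter. Among the compounds shown here, the earlier results could not show this, since compounds 1, 2 and 3 differ from one another in more than one place and gave no step to read. The change is small in size, one heavy atom for one, with a carbon leaving and an oxygen entering, and hydroxy adds a hydrogen-bond donor and acceptor that methyl lacks, though a single pair cannot tell which of these differences, if any, accounts for the step.

From the compounds shown here alone, whether the same change gives a similar step on other versions of the core remains open, as does the outcome with other groups on this nitrogen, such as methoxy, ethyl or an amino group. Compound 2 is still recorded only as a limit and not as a number, so its place in the order remains unsettled: the limit of > 65000 nM in this assay, at which 1 of the 4 values shown sits.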